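This account rests on a few compounds, and the source may have more. Where it says the series, first, only, none or still open, it means among the compounds named here.

Compound 1 `COc1ccc(-c2c(S(=O)(=O)c3cc(F)cc(F)c3)cnc3cc(F)ccc23)cc1` is measured in an ADME assay on microsomes from liver (Homo sapiens) for metabolic stability, tested at 2.5 uM (on this read-out higher numbers stand for fast clearance and lower numbers for slow clearance), and compound 1 gives 1.51 mL/min. It stands second highest of three numbers: compound 2 `COc1cccc(-c2c(S(=O)(=O)c3cc(F)cc(F)c3)cnc3cc(F)ccc23)c1` gives 1.81 mL/min, and compound 3 `O=S(=O)(c1cc(Cl)cc(Cl)c1)c1cnc2cc(F)ccc2c1-c1ccccc1F` gives 0.93 mL/min, both within the scatter of compound 1. Going by the values given here, the only single-place step on record, a 1.2-fold higher number from compound 1 to compound 2 (0.08 log units; within the scatter), moves the methoxy group on the aryl ring attached to an aromatic carbon and does not touch the sulfonyl side. Compound 4 `COc1ccc(-c2c(S(=O)(=O)c3ccc(OC)cc3)cnc3cc(F)ccc23)cc1` differs from compound 1 by 4-methoxyphenyl in place of 3,5-difluorophenyl on a sulfonyl sulfur. Among the compounds with values here, no measured step bears on this change; compound 3 differs in more than one place and offers no clean guide. For the change to compound 4 the expected step is a 1.3-fold higher number from compound 1 to compound 4 (0.12 log units; within the scatter), with a modestly higher number anticipated. The estimate for compound 4 is 2 mL/min, expected between 1.1 mL/min and 3.8 mL/min.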

Compound 4, intrinsic clearance in a liver preparation (reported as CLH), per the amount of preparation that the assay uses: 1.18 mL/min
For compound 4 the middle estimate is 1.7-fold (0.23 log units) above the measured one; the range from low to high includes it.
By their numbers in this assay, from the lowest: compounds 3, 4, 1 and 2 (each within the scatter of the next).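

In this assay, going by these compounds alone, the change on the sulfonyl sulfur gives a 1.3-fold lower number from compound 1 to compound 4 (0.11 log units; within the scatter) and so provides the first single-place reading at this position, which the earlier step left untouched. Here, 4-methoxyphenyl and 3,5-difluorophenyl cannot be told apart, even though one carries an oxygen and the other two fluorines. No measurement at hand offers an explanation for this result. Still open, going by these compounds, is whether an amine or a carboxylic acid on the sulfonyl sulfur would give a step beyond the usual scatter.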